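The source may report more compounds than this note shows. Statements on the series, on what has been measured and on what is new or still open speak of the compounds shown alone.

Of the compounds shown here, three on the shared core have numbers so far in an ADME assay on L02 cells (Homo sapiens) for antiproliferative activity, read by MTT assay, with a stated time of 48 h; a lower number here means a stronger inhibitor, a higher number a weaker inhibitor: compound 1 (`CCn1c(C(=O)N(CCC#N)CCC#N)ccc1C(CC)(CC)c1ccc(OCCC(O)(CC)CC)c(C)c1`) gives 37800 nM here, compound 2 (`CCOC(=O)C(CC(=O)OC)NC(=O)c1ccc(C(CC)(CC)c2ccc(OCCC(O)(CC)CC)c(C)c2)n1CC`) gives 4280 nM here, and compound 3 (`CCn1c(C(=O)NC(CC(=O)O)C(=O)OC)ccc1C(CC)(CC)c1ccc(OCCC(O)(CC)CC)c(C)c1`) gives 7590 nM here as well. Compound 3 therefore stands within the scatter of compound 2 and clearly apart from compound 1.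

The next change keeps the core and the carbonyl and alters only the group on the amide-type nitrogen, where 1-(hydroxymethyl)-2-methylbutyl enters in compound 4 (`CCC(C)C(CO)NC(=O)c1ccc(C(CC)(CC)c2ccc(OCCC(O)(CC)CC)c(C)c2)n1CC`). Going by the values given here, the difference is a group of 7 heavy atoms (6 carbon, 1 oxygen; no ring) in place of a group of 9 heavy atoms (5 carbon, 4 oxygen; no ring), on an amide-type nitrogen and no measured compound carries this group.

The closest evidence is a 1.8-fold higher number from compound 2 to compound 3 (0.25 log units; within the scatter) at the same nitrogen, a change that stays small. The wider steps an 8.8-fold lower number from compound 1 to compound 2 (0.95 log units; beyond the scatter) and a 5.0-fold lower number from compound 1 to compound 3 (0.70 log units; beyond the scatter) replace the whole group on the carbonyl carbon and are modest, so they serve only as a loose upper guide to the size of a change here.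

The expected step is a 1.2-fold higher number from compound 3 to compound 4 (0.07 log units; within the scatter) and this estimate means no clear move beyond the scatter, with a wide margin towards higher numbers. For compound 4 the estimated value is 9000 nM with an expected range from 3500 nM to 25000 nM in this series.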

Compound 4, half-maximal inhibitory concentration: > 50000 nM
Compound 4 gave a limit, no number (the forecaster's own chance of this, stated with the estimate: 8%); at least 5.5-fold (0.74 log units) between middle value and limit.
By their numbers in this assay, from the lowest: compounds 2 and 3 (each within the scatter of the next); then compound 1. At a limit, above all of these: compound 4.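

In this assay, compound 4 gives a limit and not a number: > 50000 nM. The amide-type nitrogen therefore does not tolerate every group equally: the change between the groups of compounds 2 and 3 gave only a 1.8-fold higher number from compound 2 to compound 3 (0.25 log units; within the scatter), whereas 1-(hydroxymethyl)-2-methylbutyl gives an at least 6.5-fold higher number from compound 3 to compound 4 (0.81 log units; beyond the scatter) and an at least 11-fold higher number from compound 2 to compound 4 (1.06 log units; beyond the scatter), both beyond the scatter. The remaining step, which also replaces the whole group on the carbonyl carbon, is an at least 1.3-fold higher number from compound 1 to compound 4 (0.12 log units; that floor lies within the scatter); its floor lies within the scatter, so it does not separate these two compounds, and the reading of all three steps rests on a floor rather than a measured size: the limit of > 50000 nM in this assay, at which 1 of the 4 values shown sits.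

As far as these compounds go, it remains open which part of 1-(hydroxymethyl)-2-methylbutyl goes with the higher number, and whether a plain 2-methylbutyl chain without the hydroxyl, or a carboxylic acid on a short chain alone, would fall with compounds 2 and 3 or with compound 4. From the compounds shown here alone, how far the true value of compound 4 lies past its limit also remains open, as does its order relative to compound 1.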